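The compounds below may be only part of what the source reports. "The series", "measured", "known", "first", "only" and "open" are said of these compounds alone.

Compound 1 `COc1cc2ncnc(Nc3ccc(F)c(Cl)c3)c2cc1OCCCCC(=O)Nc1ccc(S(N)(=O)=O)cc1`: 5020 nM
Compound 2 `C#Cc1cccc(Nc2ncnc3cc(OC)c(OCCCCC(=O)Nc4ccc(S(N)(=O)=O)cc4)cc23)c1`: 17700 nM

Of the compounds shown here, two have so far been measured in a functional assay on A-431 cells (Homo sapiens) for antiproliferative activity, read by MTT assay, with a stated time of 72 h; a lower number here means a stronger inhibitor, a higher number a weaker inhibitor. Compound 1 gives 5020 nM, and compound 2 gives 17700 nM. Going by the values given here, of these two numbers, compound 2 has the higher one, so it is the weaker inhibitor of the pair: the only step so far, a 3.5-fold higher number from compound 1 to compound 2 (0.55 log units; beyond the scatter), took place on the nitrogen on an aromatic ring and was modest but beyond the scatter.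

Compound 3 `COc1cc2ncnc(Nc3ccc(C)cc3)c2cc1OCCCCC(=O)Nc1ccc(S(N)(=O)=O)cc1` has not yet been measured. It differs from compound 2 at that same nitrogen: 4-methylphenyl in place of 3-ethynylphenyl on a nitrogen on an aromatic ring. Among the compounds with values here, no measured step compares 4-methylphenyl with either of the other two groups, so nothing bears on this change directly; the one step that exists, a 3.5-fold higher number from compound 1 to compound 2 (0.55 log units; beyond the scatter), only shows that exchanging the group on this nitrogen can move the number by a modest amount. With no direction indicated by the data, compound 3 is expected to stay near compound 2, with the step of a 1.1-fold higher number from compound 2 to compound 3 (0.05 log units; within the scatter) estimated to fall within or only slightly beyond the scatter. The estimate for compound 3 in this assay is 20000 nM, with a range from 6000 nM to 60000 nM.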

Compound 3, half-maximal inhibitory concentration: 35500 nM
For compound 3 the middle estimate is 1.8-fold (0.25 log units) below the measured one; low and high end bracket the measured number.
By their numbers in this assay, from the lowest: compound 1; then compounds 2 and 3 (each within the scatter of the next).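

In this assay, putting 4-methylphenyl in place of 3-ethynylphenyl on this nitrogen gives a 2.0-fold higher number from compound 2 to compound 3 (0.30 log units; within the scatter), so these two groups cannot be told apart, even though one carries a triple bond and the other does not. The comparison with the third group does separate them: a 7.1-fold higher number from compound 1 to compound 3 (0.85 log units; beyond the scatter), which, together with the earlier step from compound 1 to compound 2, leaves compound 1 with the 3-chloro-4-fluorophenyl group as the strongest inhibitor of the three, though all three numbers remain in the same modest range of steps. Nothing shown explains why this one group stands apart from the other two.

Compound 1 differs from the others in having both chlorine and fluorine on its phenyl ring, so a phenyl ring carrying only the chlorine or only the fluorine would be needed to show whether either atom alone accounts for the gap. The compounds shown also leave open how a non-aromatic group such as cyclohexyl on this nitrogen would behave, and whether a shorter chain at the other end of the molecule would change these numbers.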